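Notes on replacing thiophen-2-yl with 3-methoxyphenyl

This account rests on a few compounds, and the source may have more. Where it says the series, first, only, none or still open, it means among the compounds named here.

Values in a toxicity assay (Homo sapiens) for cytotoxicity, read by MTT assay, with a stated time of 48 h (on this read-out higher numbers stand for weaker inhibition and lower numbers for stronger inhibition), follow
- compound 1 `COc1ccc(C(C2=C(O)C(=O)c3ccccc3C2=O)c2c[nH]c3ccccc23)cc1Br` gives 25200 nM
- compound 2 `O=C1C(O)=C(C(c2ccc([N+](=O)[O-])cc2)c2c[nH]c3ccccc23)C(=O)c2ccccc21` gives > 200000 nM as a limit of the assay
- compound 3 `O=C1C(O)=C(C(c2cccs2)c2c[nH]c3ccccc23)C(=O)c2ccccc21` gives 31300 nM

Compound 1 and compound 3 lie within the scatter of each other, while an at least 6.3-fold lower number from compound 2 to compound 3 (0.80 log units; beyond the scatter) sets compound 2 apart. Compound 4 `COc1cccc(C(C2=C(O)C(=O)c3ccccc3C2=O)c2c[nH]c3ccccc23)c1` carries 3-methoxyphenyl in place of thiophen-2-yl on the saturated chain carbon 3-methoxyphenyl in place of thiophen-2-yl on a saturated chain carbon bound to an aromatic carbon and a double-bonded ring carbon in the shared core. Among the measured compounds shown here, the closest precedent is the exchange of 3-bromo-4-methoxyphenyl for thiophen-2-yl, a 1.2-fold higher number from compound 1 to compound 3 (0.09 log units; within the scatter) and within the scatter. The 4-nitrophenyl exchange gave an at least 7.9-fold higher number from compound 1 to compound 2 (0.89 log units; beyond the scatter) and so keeps the upper range wide. The expected change is a 1.1-fold higher number from compound 3 to compound 4 (0.05 log units; within the scatter) and no step beyond the scatter is expected. For compound 4 the estimated value is 35000 nM (expected range 14000 nM to 90000 nM).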

Compound 4, half-maximal inhibitory concentration: 110000 nM
For compound 4 the middle estimate is 3.1-fold (0.50 log units) below the measured one; the measured number lies above the stated range.
By their numbers in this assay, from the lowest: compounds 1 and 3 (each within the scatter of the next); then compound 4. At a limit, above all of these: compound 2.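

In this assay, this place on the saturated chain carbon now shows a step beyond the scatter without 4-nitrophenyl (a 3.5-fold higher number from compound 3 to compound 4 (0.55 log units; beyond the scatter)). A phenyl ring carrying methoxy therefore does not by itself keep the number of compound 1 (a 4.4-fold higher number from compound 1 to compound 4 (0.64 log units; beyond the scatter)). Against compound 2 only a floor can be read (an at least 1.8-fold lower number from compound 2 to compound 4 (0.25 log units; that floor lies within the scatter)), since the value of compound 2 is a limit of the assay: the limit of > 200000 nM in this assay, at which 1 of the 4 values shown sits.

Still open, going by these compounds, is whether the step from thiophen-2-yl follows the phenyl ring or the methoxy group on it. Unsubstituted phenyl, or an amine or carboxylic acid on that ring, would separate these.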